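A few compounds are considered here, and "the series" means these few. Any claim that something is new, unique, unknown or untested is made for them only; others in the source may bear on it.

Two measured compounds frame the question. Compound 1 `O=C(/C(=C/c1ccc(Cl)cc1)CCl)c1ccccc1` gives 17000 nM in a functional assay on T47D cells (Homo sapiens) for inhibition, read by sulforhodamine B assay, with a stated time of 48 h (on this read-out higher numbers stand for weaker inhibition of growth and lower numbers for stronger inhibition of growth), while compound 2 `O=C(/C(=C/c1ccc(Cl)cc1Cl)CCl)c1ccccc1` gives 6300 nM in this assay, and the move a 2.7-fold lower number from compound 1 to compound 2 (0.43 log units; beyond the scatter) is chloro in place of hydrogen on an aromatic carbon. Compound 2 therefore holds the lowest of the two numbers. Compound 3 `O=C(OC/C(=C\c1ccc(Cl)cc1Cl)C(=O)c1ccccc1)c1ccccc1` differs from compound 2 by benzoyloxy in place of chloro on a saturated chain carbon bound to a double-bonded chain carbon. Among the measured compounds shown here, no measured step touches this part of the molecule, so no direction can be grounded on the data. The number for compound 3 is expected to sit near that of compound 2, a step of a 1.1-fold lower number from compound 2 to compound 3 (0.02 log units; within the scatter), and compound 3 is estimated at 6000 nM, within 1500 nM to 25000 nM.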

Compound 3, concentration for 50% growth inhibition: 17000 nM
Beside the measured number, compound 3's estimate is 2.8-fold (0.45 log units) below it, and the stated range covers the measured number.
By their numbers in this assay, from the lowest: compound 2; then compounds 1 and 3 (each within the scatter of the next).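

In this assay, benzoyloxy in place of chloro on a saturated chain carbon bound to a double-bonded chain carbon gives a 2.7-fold higher number from compound 2 to compound 3 (0.43 log units; beyond the scatter) and so weakens inhibition of growth. This shows that the position is not silent, something the earlier step on the aromatic carbon could not show. Nothing shown here accounts for the change.

As far as these compounds go, it remains open whether the loss comes from chloro leaving or benzoyloxy entering. An amine or a simple hydroxyl on this carbon could settle that.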